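Geometry of the exocyclic double bond and cytotoxicity

The source may hold more compounds than are shown below. What is called first, only, known or untested is meant among the compounds shown, and "the series" means these compounds.

Measured compounds:
compound 1 `CC(=O)OC[C@H]1O[C@@H](n2cc(CN3C(=O)/C(=C\c4ccccc4)c4ccccc43)nn2)[C@H](OC(C)=O)[C@@H](OC(C)=O)[C@@H]1OC(C)=O` — 24300 nM
compound 2 `CC(=O)OC[C@H]1O[C@@H](n2cc(CN3C(=O)/C(=C/c4ccccc4)c4ccccc43)nn2)[C@H](OC(C)=O)[C@@H](OC(C)=O)[C@@H]1OC(C)=O` — 30200 nM
compound 3 `CC(=O)OC[C@H]1O[C@@H](n2cc(CN3C(=O)/C(=C/c4ccc(C)cc4)c4ccccc43)nn2)[C@H](OC(C)=O)[C@@H](OC(C)=O)[C@@H]1OC(C)=O` — > 100000 nM (a limit)

Compound 3 gives only a limit in a functional assay on MCF7 cells (Homo sapiens) for cytotoxicity, read by sulforhodamine B assay, with a stated time of 48 h (on this read-out lower numbers stand for stronger inhibition and higher numbers for weaker inhibition), namely (the limit of > 100000 nM in this assay, at which 1 of the 3 values shown sits), so its standing relative to compound 1 and compound 2 is known only as a bound. Compound 4 `CC(=O)OC[C@H]1O[C@@H](n2cc(CN3C(=O)/C(=C\c4ccc(C)cc4)c4ccccc43)nn2)[C@H](OC(C)=O)[C@@H](OC(C)=O)[C@@H]1OC(C)=O` differs from compound 3 in this way: the two compounds have the same atoms and bonds and differ only in configuration as drawn: 1 of 6 stereo elements differ; a double bond is drawn E in compound 3 and Z in compound 4. Within the data shown here, one measured step bears on this change: a 1.2-fold higher number from compound 1 to compound 2 (0.09 log units; within the scatter), which rests on (the fact that compounds 1 and 2 differ only in the configuration as drawn). From that step, no shift beyond the scatter is expected in this assay from compound 3 to compound 4, and a limit rather than a number is the more likely outcome. Compound 4 is therefore estimated at 120000 nM, with a range of 50000 nM to 300000 nM. The expected step is a step that the limit leaves unreadable from compound 3 to compound 4.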

Compound 4, half-maximal inhibitory concentration: > 100000 nM
Compound 4 gave a limit, no number; the forecaster's own chance of this, stated with the estimate: 70%; the middle value lies beyond the limit too.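

In this assay, methyl in place of hydrogen on an aromatic carbon gives an at least 4.1-fold higher number from compound 1 to compound 4 (0.61 log units; beyond the scatter), so the shift now appears with the double bond drawn Z as well as E: the same change on two cores in this assay, an at least 3.3-fold higher number (0.51 log units; beyond the scatter) from compound 2 to compound 3 and an at least 4.1-fold higher number (0.61 log units; beyond the scatter) from compound 1 to compound 4; the limit leaves it open whether they differ Compound 3 and compound 4 each sit at a limit, and the step between them cannot be read: the limit of > 100000 nM in this assay, at which 2 of the 4 values shown sit.

From the compounds shown here alone, whether double-bond geometry matters in the methyl pair therefore stays open. Also open, going by these compounds, is how an amine or a carboxylic acid in place of that methyl would behave in this assay.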